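One Added Methyl on the Lowest-Valued Compound

The source may hold more compounds than are shown below. What is called first, only, known or untested is meant among the compounds shown, and "the series" means these compounds.

- Compound 1 `O=C(Nc1ccc(CN2Cc3ccccc3C2=O)cc1)N1CC(c2cccnc2)C1`: 0.6 nM
- Compound 2 `C[C@H](NC(=O)C1CCOCC1)c1ccc(NC(=O)N2CC(c3cncc(N)c3)C2)cc1`: 500 nM
- Compound 3 `COc1nc2ccccc2n1Cc1ccc(NC(=O)N2CC(c3cccnc3)C2)cc1`: 0.2 nM

All three values come from a functional assay on A2780 cells (Homo sapiens) for antiproliferative activity, read by CellTiter-Glo, with a stated time of 72 h; a higher number here means a weaker inhibitor, a lower number a stronger inhibitor. Among these measurements, compound 3 has the lowest number, 0.2 nM, and so is the strongest inhibitor of the three. Compound 1 follows at 0.6 nM, a gap beyond the scatter of repeated measurements. Compound 2 lies much further up at 500 nM.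

The next compound, compound 4 `CCOc1nc2ccccc2n1Cc1ccc(NC(=O)N2CC(c3cccnc3)C2)cc1`, changes the methoxy of compound 3 to ethoxy. This places methyl in place of hydrogen on a saturated chain carbon bound to an oxygen on an aromatic ring. Going by the values given here, no two measured compounds differ in just one place, so no measured step shows what this change does. The expectation therefore starts from compound 3 at 0.2 nM and rests on how small the change is, which makes it uncertain. The expected 1.5-fold higher number from compound 3 to compound 4 (0.18 log units; within the scatter) is small, perhaps a slight rise in the number, and is not expected to go beyond the scatter in this assay. For compound 4 the estimated value is 0.3 nM, with an expected range from 0.1 nM to 1 nM.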

Compound 4, half-maximal inhibitory concentration: 0.7 nM
Compound 4: the middle estimate sits 2.3-fold (0.37 log units) below what was measured; the measured number falls inside the stated range.
By their numbers in this assay, from the lowest: compound 3; then compounds 1 and 4 (each within the scatter of the next); then compound 2.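

In this assay, going by these compounds alone, the added methyl gives a 3.5-fold higher number from compound 3 to compound 4 (0.54 log units; beyond the scatter), the first step in this set where only one place changes. It shows that this position, a saturated chain carbon bound to an oxygen on an aromatic ring, is sensitive to change: a single extra carbon, turning methoxy into ethoxy, moves the number beyond the usual scatter, although the step is only modest and compound 4 still stands at 0.7 nM. Nothing measured here bears on what lies behind this rise.

A single step gives a direction for this one pair and no trend, so the compounds shown leave open whether a longer chain such as propoxy, or a branched one such as isopropoxy, would raise the number further or leave it unchanged. They also leave open how this position would respond to a group of a different kind in place of methoxy, such as an amine or a hydroxyl, and so whether the rise seen here is specific to adding carbon.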